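The source may hold more compounds than are shown below. What is called first, only, known or untested is meant among the compounds shown, and "the series" means these compounds.

Measured so far:
compound 1 `COc1cc(/C(F)=C\c2cc(O)c3ccsc3c2)cc(OC)c1OC`: 23 nM
compound 2 `COc1ccc(/C=C(\F)c2cc(OC)c(OC)c(OC)c2)cc1[N+](=O)[O-]`: 2800000 nM

In a functional assay on cells (Endothelial cell, Bos taurus) for antiproliferative activity (a higher number here means a weaker inhibitor, a lower number a stronger inhibitor), compound 1 gives 23 nM, the lowest of the two numbers available. Compound 2 gives 2800000 nM in this assay, a gap far beyond the scatter; compound 2 differs from compound 1 in several places at once, so this pair says nothing about any single change. Compound 3 `COc1cc(/C(F)=C/c2cc(O)c3ccsc3c2)cc(OC)c1OC` is the next compound to be measured. Relative to compound 1: the two compounds have the same atoms and bonds and differ only in configuration as drawn: 1 of 1 stereo elements differ; a double bond is drawn E in compound 1 and Z in compound 3. Among the compounds with values here, no step between two measured compounds isolates this kind of change, so the expectation rests on general experience with this assay rather than on a measured pair. A marked weakening in this assay is expected for compound 3, with wide uncertainty about its size. For compound 3 the estimated value is 8000 nM, expected to lie between 800 nM and 150000 nM. The expected step is a 350-fold higher number from compound 1 to compound 3 (2.54 log units; beyond the scatter).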

Compound 3, half-maximal inhibitory concentration: 390 nM
Compound 3: the middle estimate sits 21-fold (1.31 log units) above what was measured; measured number below the stated range.
By their numbers in this assay, from the lowest: compound 1; then compound 3; then compound 2.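

In this assay, within the data shown here, the double bond is the first place where a single change can be read: the drawn E to Z switch gives a 17-fold higher number from compound 1 to compound 3 (1.23 log units; beyond the scatter). The whole step belongs to the configuration of the double bond, because no other part of the structure changes: the fact that compounds 1 and 3 differ only in the configuration as drawn. Configuration therefore matters in this series, yet compound 3 still gives 390 nM, so the Z form keeps measurable activity.

The data do not show why the configuration matters, or whether a step of this size would recur with other substituents on the shared core. On these data alone, the effect of replacing the hydroxyl of compound 1 with an amine or a carboxylic acid also remains open, in either configuration of the double bond.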